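This account rests on a few compounds, and the source may have more. Where it says the series, first, only, none or still open, it means among the compounds named here.

Working notes on the series. Of the compounds shown here, three have numbers so far in a functional assay on ovarian cells (Homo sapiens) for antiproliferative activity; a higher number here means a weaker inhibitor of growth, a lower number a stronger inhibitor of growth: compound 1 (`Cc1cn2c(/C=N/NC(=N)N)c(-c3cccnc3)nc2s1`) gives 15800 nM, compound 2 (`Cc1sc2nc(-c3ccccn3)c(/C=N/NC(=N)N)n2c1C`) gives 18600 nM, and compound 3 (`N=C(N)N/N=C/c1c(-c2ccccn2)nc2sc(Cl)cn12`) gives 7080 nM. Compound 3 has the lowest number of the three, and its gap to each of the other two lies beyond the scatter.

The next step leads to compound 4 (`N=C(N)N/N=C/c1c(-c2cccnc2)nc2sc(Cl)cn12`), which has pyridin-3-yl in place of pyridin-2-yl on an aromatic carbon of compound 3: pyridin-3-yl in place of pyridin-2-yl on an aromatic carbon. Going by the values given here, no measured pair isolates this exchange. Compound 1, at 15800 nM, carries pyridin-3-yl, and compound 2, at 18600 nM, carries pyridin-2-yl. These two values lie within the scatter of each other, but the two compounds also differ elsewhere on the shared core, so they offer only weak guidance.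

On this limited evidence, no step beyond the scatter is expected in this assay, and no direction can be favoured. The expected change is a 1.1-fold higher number from compound 3 to compound 4 (0.03 log units; within the scatter). The estimated value for compound 4 is 7500 nM, with an expected range from 3500 nM to 15000 nM.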

Compound 4, concentration for 50% growth inhibition: 15500 nM
The estimate for compound 4 lay 2.1-fold (0.32 log units) below the measured number, and the stated range ends below it.
By their numbers in this assay, from the lowest: compound 3; then compounds 4, 1 and 2 (each within the scatter of the next).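

In this assay, the exchange of pyridin-2-yl for pyridin-3-yl on this aromatic carbon now has a direct reading with the rest of the molecule fixed: a 2.2-fold higher number from compound 3 to compound 4 (0.34 log units; beyond the scatter), a modest step beyond the scatter, so the position of the ring nitrogen in this pyridine does register here. The other single change, chloro in place of methyl on an aromatic carbon with pyridin-3-yl held in place, gives a 1.0-fold lower number from compound 1 to compound 4 (0.01 log units; within the scatter), which lies within the scatter, so in this pair the exchange of methyl for chloro does not separate the two compounds. Nothing available explains why the pyridine exchange shifts the number.

Whether chloro in place of methyl behaves the same way with pyridin-2-yl attached stays open, since the compounds shown offer no pair that isolates it. Also open, as far as these compounds go, is how pyridin-4-yl or a plain phenyl ring on the same carbon would compare with compound 3 and compound 4, and so whether pyridin-2-yl is a particular optimum or simply one of several acceptable groups at this position.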